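Pyridin-4-yl for 4-methoxyphenyl: expectation for compound 4

The compounds below may be only part of what the source reports. "The series", "measured", "known", "first", "only" and "open" are said of these compounds alone.

Measured so far:
- compound 1 `C=CC(=O)Nc1cccc(Nc2nc(N/N=C/c3ccc(F)cc3F)ncc2Cl)c1` gives 4760 nM in an ADME assay on HT-29 cells (Homo sapiens) for inhibition, read by MTT assay, with a stated time of 72 h; a higher number here means a weaker inhibitor, a lower number a stronger inhibitor
- compound 2 `C=CC(=O)Nc1cccc(Nc2nc(N/N=C(\C)c3ccc(F)cc3)ncc2Cl)c1` gives 5050 nM in this assay
- compound 3 `C=CC(=O)Nc1cccc(Nc2nc(N/N=C(\C)c3ccc(OC)cc3)ncc2Cl)c1` gives 4560 nM in this assay

All three numbers sit together: the step of a 1.1-fold higher number from compound 1 to compound 2 (0.03 log units; within the scatter) and the step of a 1.1-fold lower number from compound 2 to compound 3 (0.04 log units; within the scatter) are both within the scatter, so compound 3 is not separated from compound 1 or compound 2 in this assay; nothing here ranks the three.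

Compound 4 `C=CC(=O)Nc1cccc(Nc2nc(N/N=C(\C)c3ccncc3)ncc2Cl)c1` is not yet measured. Relative to compound 3 the change is pyridin-4-yl in place of 4-methoxyphenyl on a carbon with a double bond to nitrogen. For the measured compounds named here, two measured steps bear on it, both touching the same aromatic group on the carbon with a double bond to nitrogen: the exchange of one six-membered carbon ring for another, a 1.1-fold higher number from compound 1 to compound 2 (0.03 log units; within the scatter), and the exchange of a substituent on that ring, a 1.1-fold lower number from compound 2 to compound 3 (0.04 log units; within the scatter). Neither moved the number beyond the scatter. Going by the values given here, no measured step replaces the carbon-only ring by a ring with a hetero atom, so the new element of the change is untested.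

On that basis no step beyond the scatter is expected for a 1.0-fold higher number from compound 3 to compound 4 (0.01 log units; within the scatter) in this assay, and compound 4 is estimated at 4700 nM, within 2000 nM to 11000 nM.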

Compound 4, half-maximal inhibitory concentration: 12800 nM
Compound 4: the middle estimate sits 2.7-fold (0.44 log units) below what was measured; the whole stated range lies below it.
By their numbers in this assay, from the lowest: compounds 3, 1 and 2 (each within the scatter of the next); then compound 4.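

In this assay, the aromatic group on the carbon with a double bond to nitrogen now shows a change beyond the scatter: pyridin-4-yl in place of 4-methoxyphenyl gives the step (a 2.8-fold higher number from compound 3 to compound 4 (0.45 log units; beyond the scatter)), and pyridin-4-yl in place of 4-fluorophenyl gives the step (a 2.5-fold higher number from compound 2 to compound 4 (0.40 log units; beyond the scatter)). The comparison with the difluorinated aldehyde-derived group of compound 1 points the same way (a 2.7-fold higher number from compound 1 to compound 4 (0.43 log units; beyond the scatter)), so compound 4 is a weaker inhibitor than each of the three compounds with a carbon-only ring, while exchanges among those carbon-only rings had stayed within the scatter. No measurement among the data shown accounts for this step.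

The compounds shown leave open whether the step follows the hetero atom in the ring or the absence of a substituent on it, a question that a plain phenyl group on the same carbon would address. Also open, on these data alone, is how the number responds to pyridin-3-yl, pyrimidin-5-yl, 4-aminophenyl or 4-carboxyphenyl on that carbon, and so whether the change seen with pyridin-4-yl extends beyond this one ring.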